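The source may hold more compounds than are shown below. What is called first, only, known or untested is meant among the compounds shown, and "the series" means these compounds.

Of the compounds shown here, three with a shared core have been measured in a functional assay on 786-0 cells (Homo sapiens) for inhibition, read by sulforhodamine B assay, with a stated time of 48 h; on this read-out lower numbers stand for stronger inhibition of growth and higher numbers for weaker inhibition of growth. Compound 1 `COc1ccc(-c2cc(/C=C/C(=O)c3ccc(N)cc3)[nH]n2)cc1` gives 2120 nM in this assay. Compound 2 `COc1cc(-c2cc(/C=C/C(=O)c3ccc(Cl)c(Cl)c3)[nH]n2)cc(OC)c1OC` gives 10100 nM, and compound 3 `COc1ccc(C(=O)/C=C/c2cc(-c3cc(OC)c(OC)c(OC)c3)n[nH]2)cc1OC` gives 1400 nM. Among these three numbers compound 1 stands second highest: its gap to compound 3 is within the usual scatter, while compound 2 sits clearly higher than compound 1, beyond the scatter.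

Compound 4 `COc1ccc(-c2cc(/C=C/C(=O)c3ccc(N)cc3)[nH]n2)cc1OC` is not yet measured. It differs from compound 1 in one place: methoxy in place of hydrogen on an aromatic carbon. Among the compounds with values here, the only measured step among the three, a 7.2-fold lower number from compound 2 to compound 3 (0.86 log units; beyond the scatter), swaps the whole aryl group on the carbonyl carbon rather than adding a single methoxy to the aryl group on the other side of the core, so it speaks only loosely to the change from compound 1 to compound 4. Nothing measured here shows the effect of a second methoxy on that ring. The expectation is therefore no step beyond the scatter, a 1.2-fold lower number from compound 1 to compound 4 (0.07 log units; within the scatter). Compound 4 is estimated at 1800 nM in this assay, with a range from 600 nM to 5500 nM.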

Compound 4, concentration for 50% growth inhibition: 1880 nM
For compound 4 the middle estimate is 1.0-fold (0.02 log units) below the measured one; the range from low to high includes it.
By their numbers in this assay, from the lowest: compounds 3, 4 and 1 (each within the scatter of the next); then compound 2.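

Placing a methoxy group in place of hydrogen on an aromatic carbon, ortho to a methoxy group and meta to a large group, gives a 1.1-fold lower number from compound 1 to compound 4 (0.05 log units; within the scatter) in this assay, so this read-out does not separate the two compounds. Within the data shown here, this is the first direct look at a single change on this ring, since the earlier step concerned the aryl group on the carbonyl carbon, and it shows that this position can carry a methoxy group without a step beyond the usual scatter. No separate measurement here bears on why the number stays within the scatter.

Still open, on these data alone, is whether other groups at this same place, such as ethoxy, hydroxyl, fluorine or an amine, would also stay within the scatter or would give a real step. Also open, as far as these compounds go, is whether the same methoxy change would give so small a step with a different aryl group on the carbonyl carbon, such as 3,4-dichlorophenyl or 3,4-dimethoxyphenyl.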